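The source may hold more compounds than are shown below. What is called first, only, known or untested is meant among the compounds shown, and "the series" means these compounds.

Compound 2 `O=C(NCc1ccncc1)Nc1ccc(S(=O)(=O)N2CC3CCC(C2)O3)cc1` holds the lowest number of the three measured compounds in an assay on isolated protein for activation of Nicotinamide phosphoribosyltransferase (Homo sapiens); on this read-out higher numbers stand for an effect only at larger amounts of compound and lower numbers for an effect already at smaller amounts: in this assay compound 2 gives 279 nM. Compound 1 `CCOC(=O)c1ccc(NC(=O)NCc2c[nH]nn2)cc1` gives 7750 nM, a gap from compound 2 that lies beyond the usual scatter, and compound 3 `CCOC(=O)c1ccc(N/C(=N\C#N)NCc2ccncc2)cc1` gives 41400 nM, the furthest of the three from compound 2. No pair among these three differs in a single place, so the three numbers stand side by side without a measured step between them.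

Compound 4 `CCN(C1CCCC1)S(=O)(=O)c1ccc(NC(=O)NCc2ccncc2)cc1` has not yet been measured. It differs from compound 2 in one place: a group of 8 heavy atoms (7 carbon, 1 nitrogen; one five-membered non-aromatic ring of carbon only) in place of a group of 8 heavy atoms (6 carbon, 1 nitrogen, 1 oxygen; one five-membered non-aromatic ring with 1 hetero atom, one six-membered non-aromatic ring with 2 hetero atoms), on a sulfonyl sulfur. The rest of the molecule, including the pyridinylmethyl urea, is kept.

For the measured compounds named here, with no measured step of this kind to lean on, compound 4 is expected to land in the same region as compound 2, most likely within the scatter or slightly toward a higher number. The estimated step from compound 2 to compound 4 is a 1.4-fold higher number from compound 2 to compound 4 (0.16 log units; within the scatter). For compound 4 the expected value in this assay is 400 nM, with a range from 120 nM to 1500 nM.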

Compound 4, half-maximal effective concentration: 60 nM
Beside the measured number, compound 4's estimate is 6.7-fold (0.82 log units) above it, and the stated range ends above it.
By their numbers in this assay, from the lowest: compound 4; then compound 2; then compound 1; then compound 3.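

For the compounds shown here, the step is the first measured change at this position, on a sulfonyl sulfur, with the pyridinylmethyl urea kept: in this assay, cyclopentyl(ethyl)amino entering there gives a 4.7-fold lower number from compound 2 to compound 4 (0.67 log units; beyond the scatter). The read-out therefore responds to the group on the sulfonyl sulfur even at an equal count of 8 heavy atoms, with one five-membered non-aromatic ring of carbon only and 0 hydrogen-bond acceptors entering, and two non-aromatic rings with hetero atoms and 1 hydrogen-bond acceptor leaving. Nothing measured here accounts for the change.

This single step leaves open which part of the exchange carries the difference, whether the loss of the ring oxygen, the ring count or the ethyl chain. On these data alone, how a morpholine or a diethylamino group on the same sulfonyl sulfur would read also remains open.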